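Fluoro to methyl on the aryl group of compound 1

The source may hold more compounds than are shown below. What is called first, only, known or untested is meant among the compounds shown, and "the series" means these compounds.

Compound 1 `O=C(CSc1ncccn1)N/N=c1/scc(-c2ccc(F)cc2)n1-c1ccccc1` reaches only a limit in an ADME assay on NIH3T3 cells (Mus musculus) for cytotoxicity, read by MTT assay, with a stated time of 24 h (on this read-out higher numbers stand for weaker inhibition and lower numbers for stronger inhibition), where compound 1 gives > 500 ug/mL; this is the assay limit and not a number, as noted in the limit of > 500 ug/mL in this assay, at which 1 of the 2 values shown sits. Compound 2 `O=C(CSc1nnnn1-c1ccccc1)N/N=c1/scc(-c2ccc(F)cc2)n1-c1ccccc1` differs at the sulfur: in this assay compound 2 gives 207 ug/mL, and the step of an at least 2.4-fold lower number from compound 1 to compound 2 (0.38 log units; beyond the scatter) is beyond the scatter. Compound 3 `Cc1ccc(-c2cs/c(=N/NC(=O)CSc3ncccn3)n2-c2ccccc2)cc1` is not yet measured and differs from compound 1 by methyl in place of fluoro on an aromatic carbon. Among the compounds with values here, no measured step touches this position: the step of an at least 2.4-fold lower number from compound 1 to compound 2 (0.38 log units; beyond the scatter) concerns the group on the sulfur and does not bear on the aryl change. With no guidance from the measured pair, no step beyond the scatter is expected, so the step that the limit leaves unreadable from compound 1 to compound 3 is estimated near zero. Compound 3 is therefore expected to give about 600 ug/mL in this assay, within 250 ug/mL to 1500 ug/mL, most likely again only as a limit.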

Compound 3, half-maximal inhibitory concentration: > 500 ug/mL
Compound 3: only a limit was reported (the forecaster's own chance of this, stated with the estimate: 65%); the middle value lies beyond the limit too.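

No step from compound 1 to compound 3 can be read in this assay, because both compounds stop at a limit of the assay and not at a number: the limit of > 500 ug/mL in this assay, at which 2 of the 3 values shown sit.

As far as these compounds go, whether 4-methylphenyl in place of 4-fluorophenyl changes the read-out at all remains open, with no number on either side of this pair.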